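Swapping the Aryl Group on the Ring Nitrogen

This account rests on a few compounds, and the source may have more. Where it says the series, first, only, none or still open, it means among the compounds named here.

Measured so far:
compound 1 `CC1SC(c2cccc(C(=O)NCCCCc3ccccc3)c2)N(c2ccc(C3CC3)cc2)C1=O`: 2010 mL.min-1.g-1
compound 2 `O=C(NCCCCc1ccccc1)c1cccc(C2SCC(=O)N2c2cccc(-c3c[nH]nn3)c2)c1`: 261 mL.min-1.g-1

In an ADME assay on microsomes from liver (Homo sapiens) for metabolic stability, read by LC-MS, using NADPH, with a stated time of 10 min, tested at 0.1 uM (a lower number here means slower removal, a higher number faster removal of the compound), compound 1 gives 2010 mL.min-1.g-1, the higher of the two numbers measured; in the same assay compound 2 gives 261 mL.min-1.g-1, a lower number that lies beyond the scatter, so compound 1 is the more quickly removed of the pair. Compound 2 differs from compound 1 in more than one place, so its number serves only as a point of reference.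

Compound 3 `COc1ccccc1N1C(=O)C(C)SC1c1cccc(C(=O)NCCCCc2ccccc2)c1` keeps the shared core of compound 1 and changes a single group: 2-methoxyphenyl in place of 4-cyclopropylphenyl on an amide-type nitrogen in a ring

Among the compounds with values here, no step between measured compounds matches this change, so the direction rests on the change itself and on the spread of numbers seen so far. Both measured numbers are high, and compound 2 shows that a different aryl group on the ring nitrogen can bring the number down. Compound 3 is therefore expected to land somewhat below compound 1, a step of a 1.8-fold lower number from compound 1 to compound 3 (0.26 log units; within the scatter), with a wide range: an estimated 1100 mL.min-1.g-1, between 450 mL.min-1.g-1 and 2800 mL.min-1.g-1.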

Compound 3, intrinsic clearance in microsomes in the Homo sapiens assay: 2660 mL.min-1.g-1
Compound 3: the middle estimate sits 2.4-fold (0.38 log units) below what was measured; the measured number falls inside the stated range.
By their numbers in the Homo sapiens assay, from the lowest: compound 2; then compounds 1 and 3 (each within the scatter of the next).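

Within the data shown here, in the Homo sapiens assay, this is the first single-change comparison at the amide-type nitrogen in a ring, and the step is a 1.3-fold higher number from compound 1 to compound 3 (0.12 log units; within the scatter), so replacing 4-cyclopropylphenyl with 2-methoxyphenyl does not separate the two compounds on this read-out. Among these compounds, in a physicochemical assay for solubility, read by turbidimetry, measured as kinetic solubility, at pH 7.4 (on this read-out higher numbers stand for higher solubility and lower numbers for lower solubility), compound 1 gives 2000 nM and compound 3 gives 10000 nM, which is the first sign that a change at this position can register on one read-out and not on the other. The same swap, which leaves the clearance numbers within the scatter of each other, does separate the two compounds on solubility: the measured solubility of compound 1, 2000 nM, and of compound 3, 10000 nM, a 5.0-fold higher number (0.70 log units; beyond the scatter)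

The compounds shown do not tell whether the methoxy group or the loss of the cyclopropyl ring carries the solubility step, as both changes arrive together. From the compounds shown here alone, compound 2 differs from compound 1 in more than one place, so what lies behind its lower number stays open, as does whether a simple amine or a carboxylic acid on the phenyl ring would bring the clearance number down.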